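The source may hold more compounds than are shown below. What is called first, only, known or untested is meant among the compounds shown, and "the series" means these compounds.

Series notes. Compound 1 `Cc1noc(C)c1S(=O)(=O)N1CCC(N2CCC(C)CC2)CC1` carries a 3,5-dimethyl-1,2-oxazol-4-yl group on the sulfonyl sulfur of the shared core. In an ADME assay on HCT-116 cells (Homo sapiens) for cytotoxicity, read by CellTiter-Glo, with a stated time of 72 h (on this read-out higher numbers stand for weaker inhibition and lower numbers for stronger inhibition), compound 1 gives > 10000 nM, which is a limit of the assay and not a number (the limit of > 10000 nM in this assay, at which 1 of the 2 values shown sits). Compound 2 `CC1CCN(C2CCN(S(=O)(=O)c3cc(F)c(Br)c(F)c3)CC2)CC1` is the other measured member of the set. In this assay compound 2 gives > 5000 nM, again a limit rather than a number (the limit of > 5000 nM in this assay, at which 1 of the 2 values shown sits). On the numbers shown, compound 1 stands at a limit, and because both values are limits, no order between compound 1 and compound 2 can be read and no step between two measured numbers exists here.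

Compound 3 `CC1CCN(C2CCN(S(=O)(=O)c3cc(Cl)cc(Cl)c3)CC2)CC1` has not yet been run in this assay. Compound 3 differs from compound 1 in one place (3,5-dichlorophenyl in place of 3,5-dimethyl-1,2-oxazol-4-yl on a sulfonyl sulfur). For the measured compounds named here, no measured step joins these two, so the size of the change in this assay is open; with compound 1 sitting at a limit, no move beyond the scatter in either direction can be read from the data, and the expectation is that compound 3 again returns a limit or a weak number. The estimate for compound 3 in this assay is 15000 nM, with a range from 4000 nM to 50000 nM. The step this estimate implies is expected to be a step that the limit leaves unreadable from compound 1 to compound 3.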

Compound 3, half-maximal inhibitory concentration: > 5000 nM
Compound 3 ended at the assay's limit (the forecaster's own chance of this, stated with the estimate: 75%); the middle value lies beyond the limit too.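

In this assay compound 3 gives > 5000 nM, a limit of the assay and not a number. No step between compound 1 and compound 3 can be read, as compound 1 also sits at a limit: the limit of > 10000 nM in this assay, at which 1 of the 3 values shown sits.

The compounds shown leave open whether 3,5-dichlorophenyl in place of 3,5-dimethyl-1,2-oxazol-4-yl on a sulfonyl sulfur changes the read-out at all.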